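Pyridin-3-yl in place of cyclohexyl on the piperazine nitrogen

A few compounds are considered here, and "the series" means these few. Any claim that something is new, unique, unknown or untested is made for them only; others in the source may bear on it.

Compound 1, `Nc1ccccc1NC(=O)c1ccc(CSC(=S)N2CCN(C3CCCCC3)CC2)cc1`, gives 76.1% in a functional assay on HeLa cells (Homo sapiens) for antiproliferative activity, read by CCK-8 assay, with a stated time of 72 h, tested at 8 uM; a lower number here means a weaker effect, a higher number a stronger effect of the compound at the concentration tested.
Compound 2, `Nc1ccccc1NC(=O)c1ccc(CSC(=S)N2CCc3ccc([N+](=O)[O-])cc32)cc1`, gives 62.1% in this assay.
Compound 3, `Nc1ccccc1NC(=O)c1ccc(CSC(=S)N2CCN(C(c3ccccc3)c3ccccc3)CC2)cc1`, gives 13.8% in this assay.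

Compound 1 stands highest of the three numbers in this assay; compound 2 comes nearest, with a number lower by a gap beyond the scatter, and compound 3 lies furthest, far below it. Compound 4, `Nc1ccccc1NC(=O)c1ccc(CSC(=S)N2CCN(c3cccnc3)CC2)cc1`, has not yet been measured in this assay. It differs from compound 1 in one place: pyridin-3-yl in place of cyclohexyl on an amine nitrogen in a ring. Going by the values given here, no step between measured compounds matches this change, so the expectation rests on what the three numbers show. A moderate fall from compound 1 is expected, as the step of a number 21.1 percentage points lower from compound 1 to compound 4 (beyond the scatter), because compound 1 gives 76.1% while compound 3 , carrying a different group on the same ring nitrogen, gives 13.8%. Compound 4 is therefore estimated at 55%, within a range from 25% to 80%.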

Compound 4, a percentage reported as inhibition, at one concentration (the size of the read-out at that concentration, not a potency): 72.5%
Beside the measured number, compound 4's estimate is 17.5 percentage points below it; the range from low to high includes it.
By their numbers in this assay, from the lowest: compound 3; then compound 2; then compounds 4 and 1 (each within the scatter of the next).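

Placing pyridin-3-yl in place of cyclohexyl on the amine nitrogen in a ring gives a number 3.6 percentage points lower from compound 1 to compound 4 (within the scatter) in this assay, the first step at this position that changes one group alone. This position therefore takes an aromatic ring carrying a hydrogen-bond acceptor as well as a non-aromatic ring of carbon only, and an aromatic ring on this nitrogen does not by itself bring the read-out down to that of compound 3 at 13.8%. Nothing given here explains why the two groups read alike.

On these data alone, it remains open whether a plain phenyl, a pyridin-2-yl or a pyridin-4-yl on the same nitrogen would read like pyridin-3-yl. Also open, as far as these compounds go, is how far a small methyl or an acetyl group there would hold the number.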